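From compound 3 to compound 4: one added methyl

The source may hold more compounds than are shown below. What is called first, only, known or untested is meant among the compounds shown, and "the series" means these compounds.

In a functional assay on MDA-MB-231 cells (Homo sapiens) for inhibition, read by sulforhodamine B assay, with a stated time of 74 h (on this read-out higher numbers stand for weaker inhibition and lower numbers for stronger inhibition), compound 3 `O=C1C=CC2(C=C1)OCC(=O)N2S(=O)(=O)c1cccs1` gives 20 nM, the lower of the two exact numbers, while compound 1 `Cc1ccc(S(=O)(=O)N2C(=O)C(C)OC23C=CC(=O)C=C3)cc1` gives 1100 nM. Compound 2 `Cc1ccccc1S(=O)(=O)N1C(=O)COC12C=CC(=O)C=C2` reads > 10000 nM, which is a limit. For the measured compounds named here, the one measured step, an at least 500-fold lower number from compound 2 to compound 3 (2.69 log units; beyond the scatter), is large and beyond the scatter, but it concerns the sulfonyl substituent, not the site changed next. Compound 4 `CC1OC2(C=CC(=O)C=C2)N(S(=O)(=O)c2cccs2)C1=O` keeps the thiophen-2-yl group and differs by methyl in place of hydrogen on a saturated ring carbon. Compound 1 carries this methyl with another sulfonyl substituent and gives 1100 nM, so it offers only indirect guidance. A modest rise in this assay is expected, a 2.5-fold higher number from compound 3 to compound 4 (0.40 log units; beyond the scatter). The number for compound 4 is estimated at 50 nM, within 12 nM to 250 nM.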

Compound 4, half-maximal inhibitory concentration: > 10000 nM
Compound 4 gave a limit, no number; the forecaster's own chance of this, stated with the estimate: 3%; at least 200-fold (2.30 log units) between middle value and limit.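

In this assay, methyl in place of hydrogen on the saturated ring carbon next to the ring oxygen gives an at least 500-fold higher number from compound 3 to compound 4 (2.69 log units; beyond the scatter), so with thiophen-2-yl on the sulfonyl sulfur this single carbon decides between strong inhibition and none detected. With that methyl present, thiophen-2-yl in place of 4-methylphenyl gives an at least 9.0-fold higher number from compound 1 to compound 4 (0.95 log units; beyond the scatter), the opposite direction to the step from 2-methylphenyl to thiophen-2-yl among the compounds without it. Both new steps are bounds and not exact sizes, since compound 4 reads a limit: the limit of > 10000 nM in this assay, at which 2 of the 4 values shown sit.

The compounds shown leave open whether an ethyl or a hydroxyl group on this carbon would behave like methyl. They also leave open how 4-methylphenyl on the sulfonyl sulfur reads without the methyl.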